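The source may hold more compounds than are shown below. What is called first, only, known or untested is meant among the compounds shown, and "the series" means these compounds.

Measured in a functional assay on DU-145 cells (Homo sapiens) for inhibition, read by trypan blue exclusion, with a stated time of 96 h; on this read-out higher numbers stand for weaker inhibition of growth and lower numbers for stronger inhibition of growth:
- compound 1 `O=C(O)c1ccc(C(=O)/C(=C\c2ccc(F)c([N+](=O)[O-])c2)SCc2ccc(Cl)cc2Cl)cc1` gives 1000 nM
- compound 2 `CN(C)c1ccc(/C=C(/SCc2ccc(Br)cc2)C(=O)c2ccc(C(=O)O)cc2)cc1` gives 50000 nM
- compound 3 `O=C(O)c1ccc(C(=O)/C(=C\c2ccc(F)c([N+](=O)[O-])c2)SCc2ccc(F)cc2)cc1` gives 1000 nM

Compound 3 stands level with compound 1, and together they hold the lowest number of the three, while compound 2 has a much higher number. The next compound, compound 4 (`CN(C)c1ccc(/C=C(/SCc2ccc(F)cc2)C(=O)c2ccc(C(=O)O)cc2)cc1`), keeps everything in compound 3 except one group: 4-(dimethylamino)phenyl in place of 4-fluoro-3-nitrophenyl on a double-bonded chain carbon bound to a double-bonded chain carbon.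

For the measured compounds named here, no measured step covers this exact swap, but compound 2 (50000 nM) already carries 4-(dimethylamino)phenyl. It differs from compound 4 only in the group on the saturated chain carbon bound to a sulfur. Going by the values given here, the one measured change at that place was small (no change at the digits printed from compound 1 to compound 3 (within the scatter)), though it was seen with the other group in place. Compound 4 is therefore expected to lie close to compound 2, which means a large expected step (a 40-fold higher number from compound 3 to compound 4 (1.60 log units; beyond the scatter)) towards weaker inhibition of growth, beyond the scatter. For compound 4 the estimate is 40000 nM, with an expected range from 12000 nM to 100000 nM.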

Compound 4, concentration for 50% growth inhibition: 10000 nM
Compound 4: the middle estimate sits 4.0-fold (0.60 log units) above what was measured; measured number below the stated range.
By their numbers in this assay, from the lowest: compounds 1 and 3 (each within the scatter of the next); then compound 4; then compound 2.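

With the rest of the molecule held constant, 4-(dimethylamino)phenyl in place of 4-fluoro-3-nitrophenyl on a double-bonded chain carbon bound to a double-bonded chain carbon gives, in this assay, a 10-fold higher number from compound 3 to compound 4 (1.00 log units; beyond the scatter), so this swap weakens inhibition of growth. The halogen on the other aromatic ring also counts when 4-(dimethylamino)phenyl is present: fluoro in place of bromo gives a 5.0-fold lower number from compound 2 to compound 4 (0.70 log units; beyond the scatter), so that part of the molecule is not silent, even though the different change no change at the digits printed from compound 1 to compound 3 (within the scatter) left the number flat with 4-fluoro-3-nitrophenyl in place. Nothing available here explains either shift.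

From the compounds shown here alone, it remains open whether the nitro group, the fluoro or both on the leaving ring matter most. A methoxy group or a nitrile on the ring at this place could help separate these possibilities.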